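The compounds below may be only part of what the source reports. "The series", "measured", "known", "first", "only" and "open" are said of these compounds alone.

Compound 1, `CNc1nc(C)c(C(=O)N/N=C/c2cccc(C(F)(F)F)c2)s1`, sits in a functional assay on HepG2 cells (Homo sapiens) for inhibition, read by MTT assay, with a stated time of 72 h (on this read-out lower numbers stand for stronger inhibition and higher numbers for weaker inhibition), at a limit of the assay, > 100 ug/mL. Compound 2, `CN(C(=O)NC(=O)c1ccccc1F)c1nc(C(F)(F)F)c(C(=O)N/N=C/c2cc(C(F)(F)F)cc(C(F)(F)F)c2)s1`, gives 4.47 ug/mL. Compound 3, `CNc1nc(C)c(C(=O)N/N=C/c2cc(C(F)(F)F)cc(C(F)(F)F)c2)s1`, sits at a limit of the assay, > 100 ug/mL.

Within the data shown here, compound 3 therefore stands at the limit of > 100 ug/mL in this assay, at which 2 of the 3 values shown sit, and the only measured single change, a step that the two limits leave unreadable from compound 1 to compound 3, cannot be read. Compound 4, `CNc1nc(C(F)(F)F)c(C(=O)N/N=C/c2cc(C(F)(F)F)cc(C(F)(F)F)c2)s1`, differs from compound 3 by trifluoromethyl in place of methyl on an aromatic carbon. Among the measured compounds shown here, no measured step isolates this change; compound 2 carries a trifluoromethyl at the same place but differs from compound 3 in several other places as well, so its value shows only that a member of this series can register a number. The expected step of an at least 1.6-fold lower number from compound 3 to compound 4 (0.22 log units; that floor lies within the scatter) is thus estimated as modest and uncertain. Compound 4 is expected to give about 60 ug/mL, within 15 ug/mL to 200 ug/mL.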

Compound 4, half-maximal inhibitory concentration: > 100 ug/mL
Compound 4: only a limit was reported; the forecaster's own chance of this, stated with the estimate: 55%; middle value at least 1.6-fold (0.22 log units) away from the limit.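

With trifluoromethyl in place of methyl on the aromatic carbon next to the ring nitrogen, compound 4 stays at the limit in this assay, so the step from compound 3 cannot be read. The new pair shows that the nitrogen substituent matters: hydrogen in place of ((2-fluorophenyl)carbonyl)carbamoyl gives an at least 22-fold higher number from compound 2 to compound 4 (1.34 log units; beyond the scatter). Trifluoromethyl at this position is thus not enough to bring a number into range, and the limit remains the most common reading: the limit of > 100 ug/mL in this assay, at which 3 of the 4 values shown sit.

From the compounds shown here alone, it remains open whether methyl in compound 2's setting would also register a number. Also open, going by these compounds, is whether an acetyl group or a longer alkyl chain on that nitrogen would do so.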